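Side-chain swap from compound 3 to compound 4

This account rests on a few compounds, and the source may have more. Where it says the series, first, only, none or still open, it means among the compounds named here.

In a functional assay on Raji cells (Homo sapiens) for antiproliferative activity, read by MTT assay, with a stated time of 48 h (a higher number here means a weaker inhibitor, a lower number a stronger inhibitor), compound 1 `CCn1c(N)c(-c2nc3ccccc3[nH]2)c2nc(C#N)c(C#N)nc21` gives > 50000 nM as a limit, not a number. Compound 3 `N#Cc1nc2c(-c3nc4ccccc4[nH]3)c(N)n(CCN3CCCC3)c2nc1C#N` gives > 50000 nM and this too is only a limit. Compound 3 thus stands at the limit of > 50000 nM in this assay, at which 2 of the 3 values shown sit, and has no readable position beyond that. Compound 2 `CCN(CC)CCn1c(N)c(-c2nc3ccccc3[nH]2)c2nc(C#N)c(C#N)nc21` alone gives a number, 8950 nM in this assay on the same core.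

Compound 4 `CN1CCN(CCn2c(N)c(-c3nc4ccccc4[nH]3)c3nc(C#N)c(C#N)nc32)CC1` carries 4-methylpiperazin-1-yl in place of pyrrolidin-1-yl, on a saturated chain carbon, two bonds along the chain from an aromatic nitrogen: 4-methylpiperazin-1-yl in place of pyrrolidin-1-yl on a saturated chain carbon, two bonds along the chain from an aromatic nitrogen is the whole change.

Within the data shown here, no measured step covers this exchange directly. The closest evidence is an at least 5.5-fold higher number from compound 2 to compound 3 (0.74 log units; beyond the scatter) and an at least 5.5-fold lower number from compound 1 to compound 2 (0.74 log units; beyond the scatter) as both lie beyond the scatter and show that the group at this place can matter. The step that the two limits leave unreadable from compound 1 to compound 3 gives no size. A modest drop from the limit is expected, or no readable change, and the estimated step is an at least 1.6-fold lower number from compound 3 to compound 4 (0.22 log units; that floor lies within the scatter) in that sense. The expected value for compound 4 is 30000 nM with an estimated range from 10000 nM to 50000 nM and a reading at the limit remains quite possible.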

Compound 4, half-maximal inhibitory concentration: > 50000 nM
Compound 4: only a limit was reported; the forecaster's own chance of this, stated with the estimate: 50%; middle value at least 1.6-fold (0.22 log units) away from the limit.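

Compound 4 joins compounds 1 and 3 at a limit in this assay, and a second ring amine at this place therefore gives no readable value: the limit of > 50000 nM in this assay, at which 3 of the 4 values shown sit.

Exchanging diethylamino for 4-methylpiperazin-1-yl gives an at least 5.5-fold higher number from compound 2 to compound 4 (0.74 log units; beyond the scatter), so among the compounds shown, the readable value remains confined to the 2-(diethylamino)ethyl chain of compound 2. The steps from compound 3 to compound 4 and from compound 1 to compound 4 join limit to limit and cannot be read, so pyrrolidin-1-yl, 4-methylpiperazin-1-yl and the hydrogen of compound 1 cannot be ranked.

From the compounds shown here alone, it remains open whether other open-chain amines, such as dimethylamino or dipropylamino, would also give a readable value at this place. Going by these compounds, the effects of a ring amine such as piperidin-1-yl or morpholin-4-yl, or of a longer chain carrying diethylamino, also remain open.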